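A few compounds are considered here, and "the series" means these few. Any claim that something is new, unique, unknown or untested is made for them only; others in the source may bear on it.

Measured compounds:
compound 1 `N#CC(C#N)=Cc1ccc(CN2CCN(c3ccccc3)CC2)[nH]1` — 9.3 nM
compound 2 `N#CC(C#N)=Cc1[nH]ccc1CN1CCN(c2ccccc2)CC1` — 160 nM

In an assay on CHO cells for binding affinity to D(4) dopamine receptor (Homo sapiens), read by radioligand binding (a higher number here means a weaker inhibitor, a lower number a stronger inhibitor), compound 1 gives 9.3 nM and compound 2 gives 160 nM. Compound 2 therefore stands at the highest of the two numbers recorded; its nearest neighbour, compound 1, carries a clearly lower number, and the gap between them lies well beyond the usual scatter. For the measured compounds named here, no single-point step between measured compounds is available, so nothing measured yet shows how a substituent on the phenyl ring affects this assay.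

Compound 3 `N#CC(C#N)=Cc1[nH]ccc1CN1CCN(c2ccc(Cl)cc2)CC1` differs from compound 2 by chloro in place of hydrogen on an aromatic carbon, para to a large group. The expectation rests on the change alone and on the values of compound 1 and compound 2: a small step in this assay, more likely toward a lower number than a higher one, though possibly none beyond the scatter. Compound 3 is accordingly expected at 70 nM, with a range from 25 nM to 250 nM. The estimated step of a 2.3-fold lower number from compound 2 to compound 3 (0.36 log units; beyond the scatter) is expected to be modest.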

Compound 3, inhibition constant: 125 nM
Estimate against measurement, compound 3: 1.8-fold (0.25 log units) below; the range from low to high includes it.
By their numbers in this assay, from the lowest: compound 1; then compounds 3 and 2 (each within the scatter of the next).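

For the compounds shown here, replacing hydrogen with chloro on an aromatic carbon, para to a large group, turns phenyl into 4-chlorophenyl and gives in this assay a 1.3-fold lower number from compound 2 to compound 3 (0.11 log units; within the scatter) as the first reading of a single change. This place on the six-membered aromatic ring therefore accepts one added chlorine atom with no shift beyond the usual scatter, so in this core the chloro group neither gains nor loses measurable affinity relative to hydrogen. Nothing available explains why the step has this size.

On these data alone, what a methoxy group, an amine or a carboxylic acid would do in the same place remains open, so one chloro result does not yet show how far this place tolerates substitution in general. Also open, as far as these compounds go, is whether phenyl to 4-chlorophenyl gives a step of similar size on the core of compound 1, since the present reading applies only to the core shared by compound 2 and compound 3.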